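The source may hold more compounds than are shown below. What is called first, only, known or untested is meant among the compounds shown, and "the series" means these compounds.

Measured compounds:
Compound 1 `CCCc1ccc(NC2=CC(=O)c3nc4n(c3C2=O)[C@H]2OC[C@@H](O)[C@H]2OC4)cc1` — compound 1 in a functional assay on ECa-109 cells for inhibition, with ECa-109 cell line (Homo sapiens) as the target, read by sulforhodamine B assay; a higher number here means a weaker inhibitor, a lower number a stronger inhibitor: > 4000 nM
Compound 2 `Cc1ccc(NC2=CC(=O)c3c(nc4n3[C@H]3OC[C@@H](O)[C@H]3OC4)C2=O)cc1C` — compound 2 in this assay: 4090 nM

In this assay compound 1 reaches only a limit of the assay, > 4000 nM. Among the compounds with values here, compound 2 gives 4090 nM in this assay and is the only compound with a number rather than a limit, since (the limit of > 4000 nM in this assay, at which 1 of the 2 values shown sits). Compound 3 `O=C1C(Nc2cccc(Cl)c2)=CC(=O)c2c1nc1n2[C@H]2OC[C@@H](O)[C@H]2OC1` differs from compound 2 in that it carries 3-chlorophenyl in place of 3,4-dimethylphenyl on an amine nitrogen. Within the data shown here, no measured pair shows a change of this kind, so the step of a 1.0-fold lower number from compound 2 to compound 3 (0.01 log units; within the scatter) is expected to stay within the scatter, in no set direction. Compound 3 is therefore estimated at 4000 nM, between 1500 nM and 12000 nM.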

Compound 3, half-maximal inhibitory concentration: 3080 nM
Beside the measured number, compound 3's estimate is 1.3-fold (0.11 log units) above it; low and high end bracket the measured number.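

In this assay, exchanging 3,4-dimethylphenyl for 3-chlorophenyl on an amine nitrogen leaves the reading within the scatter (a 1.3-fold lower number from compound 2 to compound 3 (0.12 log units; within the scatter)). Within the data shown here, this is the first measured step at this position, and it does not separate the two aryl groups. Compound 1 is a limit of the assay and cannot be compared in this step: the limit of > 4000 nM in this assay, at which 1 of the 3 values shown sits.

From the compounds shown here alone, whether an amine, a carboxylic acid or a longer chain in this place would move the number beyond the scatter stays open.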